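Azetidinyl to diethylamino on the shared core

The source may hold more compounds than are shown below. What is called first, only, known or untested is meant among the compounds shown, and "the series" means these compounds.

Measured compounds:
compound 1, `N#Cc1cc(Cl)c(Nc2nc3c(Nc4ccc(C(F)(F)F)cc4)ncnc3s2)c(Cl)c1`, 53 nM
compound 2, `O=C(O)c1ccc(Nc2ncnc3sc(Nc4c(Cl)cccc4Cl)nc23)cc1`, > 5000 nM
compound 3, `FC(F)(F)c1ccc(Nc2nc(N3CCC3)nc3sc(Nc4c(Cl)cccc4Cl)nc23)cc1`, 25 nM

In a functional assay on HEK293 cells for antagonist activity at transient receptor potential cation channel subfamily V member 1 (Rattus norvegicus), read by calcium flux (a higher number here means a weaker inhibitor, a lower number a stronger inhibitor), compound 3 gives the lower of the two numbers, and compound 1 gives 53 nM, a gap just beyond the usual scatter. Compound 2 reaches only the limit of this assay at > 5000 nM, which is not a number; it sits at the limit of > 5000 nM in this assay, at which 1 of the 3 values shown sits.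

Compound 4, `CCN(CC)c1nc(Nc2ccc(C(F)(F)F)cc2)c2nc(Nc3c(Cl)cccc3Cl)sc2n1`, is not yet measured. It differs from compound 3 by diethylamino in place of azetidin-1-yl on an aromatic carbon. Within the data shown here, no measured step of this kind is available, so the expectation rests on compound 3 alone. Both groups are amines of similar size at the same place, and the expected step is none beyond the scatter, in either direction; the estimated step is a 1.2-fold higher number from compound 3 to compound 4 (0.08 log units; within the scatter). Compound 4 is therefore expected to give about 30 nM in this assay, within a range from 10 nM to 100 nM.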

Compound 4, half-maximal inhibitory concentration: 34 nM
Beside the measured number, compound 4's estimate is 1.1-fold (0.05 log units) below it, within the range that was stated.
By their numbers in this assay, from the lowest: compounds 3, 4 and 1 (each within the scatter of the next, the first and the last beyond it). At a limit, above all of these: compound 2.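

In this assay, the step at this carbon between two ring nitrogen atoms is small: a 1.4-fold higher number from compound 3 to compound 4 (0.13 log units; within the scatter). Replacing the four-membered non-aromatic ring of azetidin-1-yl with the open diethylamino group therefore leaves the number within the scatter, so the ring itself is not required for a value of this order. Nothing measured here gives a reason for this step.

From the compounds shown here alone, whether a primary amine, a morpholine ring or a longer chain such as dipropylamino would also hold the number at this carbon remains open. Compound 1 and compound 2 carry no amine at this carbon, but each also differs from compound 3 in another place, so what the amine itself contributes cannot be read from them.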